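This account rests on a few compounds, and the source may have more. Where it says the series, first, only, none or still open, it means among the compounds named here.

Measured compounds:
compound 1 `COc1cccc(NC(=O)Nc2ccc(Oc3ncnc4[nH]ncc34)cc2)c1` — 82000 nM
compound 2 `COc1cccc(NC(=O)Nc2ccc(Oc3ncnc4c3cnn4C)cc2)c1` — > 100000 nM
compound 3 `O=C(Nc1ccc(C(F)(F)F)cc1)Nc1cccc(Oc2ncnc3[nH]ncc23)c1` — > 100000 nM

In an assay on isolated protein for inhibition of vascular endothelial growth factor receptor 2 (Danio rerio), read by fluorescence and microscopy, with a stated time of 33 h (on this read-out higher numbers stand for weaker inhibition and lower numbers for stronger inhibition), compound 1 gives 82000 nM. For compound 2 the value of > 100000 nM is a limit of the assay, not a number. For compound 3 the value of > 100000 nM is likewise a limit. Compound 1 therefore stands as the only real number shown, and it is already close to the limit of > 100000 nM in this assay, at which 2 of the 3 values shown sit. Going by the values given here, the single measured step, an at least 1.2-fold higher number from compound 1 to compound 2 (0.08 log units; that floor lies within the scatter), comes from a methyl in place of hydrogen on an aromatic nitrogen, and it only shows that the value moved onto the limit. Compound 3 differs from compound 1 in more than one place, so its limit says nothing about a single change.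

Compound 4 `O=C(Nc1ccc(Oc2ncnc3[nH]ncc23)cc1)NC1CCCCC1` differs from compound 1 by cyclohexyl in place of 3-methoxyphenyl on an amide-type nitrogen. Among the compounds with values here, no measured step touches this amide-type nitrogen, so nothing here tells how large the step will be. Given that compound 1 sits at 82000 nM, compound 4 is expected to give 150000 nM, with a range from 50000 nM to 500000 nM. The expected step, a 1.8-fold higher number from compound 1 to compound 4 (0.26 log units; within the scatter), most likely ends at the limit.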

Compound 4, half-maximal inhibitory concentration: > 100000 nM
Compound 4: a limit, no number (the forecaster's own chance of this, stated with the estimate: 65%); the middle value is on the limit's open side.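

Cyclohexyl in place of 3-methoxyphenyl on an amide-type nitrogen gives an at least 1.2-fold higher number from compound 1 to compound 4 (0.08 log units; that floor lies within the scatter). Going by these compounds alone, this is the first look at this place in the molecule, since the earlier step changed an aromatic nitrogen of the core. Compound 4 carries only a limit, so the change shows that a non-aromatic ring here gives no measurable number, but it does not show how much inhibition is lost, and the assay leaves little room to show a loss from compound 1: the limit of > 100000 nM in this assay, at which 3 of the 4 values shown sit.

Whether 3-methoxyphenyl is truly needed at this place therefore stays undecided. On these data alone, it is also open whether a plain phenyl, a pyridine ring, a carboxylic acid or a longer chain such as hexyl on this nitrogen would give a clearly lower number than compound 1.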